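The source may report more compounds than this note shows. Statements on the series, on what has been measured and on what is new or still open speak of the compounds shown alone.

In a functional assay on the whole organism for agonist activity, with Mus musculus as the target (on this read-out lower numbers stand for an effect already at smaller amounts and higher numbers for an effect only at larger amounts of compound), compound 1 `CC(=O)N(C)CC#CCn1ccnc1` gives 0.97 mg/kg and compound 2 `CN(C)C(=O)N(C)CC#CCN1CCCC1` gives 1.2 mg/kg. For the measured compounds named here, these two numbers lie within the usual scatter of each other, so compound 2 stands level with the only other measured compound. Compound 3 `CN(C)C(=O)N(C)CC#CCn1ccnc1` has not been measured yet. It is compound 2 with one change: 1H-imidazol-1-yl in place of pyrrolidin-1-yl on a saturated chain carbon bound to a triple-bonded carbon. Going by the values given here, no measured pair shows what this swap does on its own. Still, compound 1 carries the same 1H-imidazol-1-yl group and gives 0.97 mg/kg in this assay, so no step beyond the scatter is expected, only a slight drift toward a higher number. The estimated change is a 1.3-fold higher number from compound 2 to compound 3 (0.10 log units; within the scatter). For compound 3 the estimated value is 1.5 mg/kg, with an expected range of 0.5 mg/kg to 5 mg/kg.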

Compound 3, dose for half-maximal effect: 11.8 mg/kg
Compound 3: the middle estimate sits 7.9-fold (0.90 log units) below what was measured; measured number outside the range, above it.
By their numbers in this assay, from the lowest: compounds 1 and 2 (each within the scatter of the next); then compound 3.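

With dimethylamino on the carbonyl carbon, the swap to 1H-imidazol-1-yl on a saturated chain carbon bound to a triple-bonded carbon is far from neutral in this assay and gives a 9.8-fold higher number from compound 2 to compound 3 (0.99 log units; beyond the scatter), so the choice of five-membered ring at this position matters. The 1H-imidazol-1-yl group alone does not settle the outcome either: dimethylamino in place of methyl on a carbonyl carbon gives a 12-fold higher number from compound 1 to compound 3 (1.09 log units; beyond the scatter), which shows that the group on the carbonyl carbon counts as well. Nothing available explains either step.

Still open, as far as these compounds go, is how pyrrolidin-1-yl behaves with methyl on the carbonyl carbon, which would show whether the two changes act independently. Also open, from the compounds shown here alone, is whether a piperidin-1-yl group at the chain carbon would stay level with compound 2.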